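A few compounds are considered here, and "the series" means these few. Any claim that something is new, unique, unknown or untested is made for them only; others in the source may bear on it.

Compound 2, `COC(=O)/C=C/c1cccc(N(Cc2ccc(-c3cccc(Cl)c3)cc2)C(=O)C2CCCCC2)c1`, gives 94 nM in an assay on isolated protein with Bile acid receptor (Homo sapiens) as the target; on this read-out lower numbers stand for an effect already at smaller amounts and higher numbers for an effect only at larger amounts of compound; it stands at the highest of the three numbers, though its gaps to compound 3 and to compound 1 both lie within the scatter. Compound 3, `COC(=O)/C=C/c1cccc(N(Cc2ccc(-c3cccc(Cl)c3)cc2)C(=O)C(C)C)c1`, gives 77 nM, and compound 1, `COC(=O)/C=C/c1cccc(N(Cc2ccc(/C=C/c3cccc(F)c3)cc2)C(=O)C(C)C)c1`, gives 71 nM. The step to compound 4, `COC/C=C/c1ccc(CN(C(=O)C2CCCCC2)c2cccc(/C=C/C(=O)OC)c2)cc1`, is 3-methoxyprop-1-en-1-yl in place of 3-chlorophenyl on an aromatic carbon. Within the data shown here, two measured steps bear on it only loosely. The change a 1.1-fold higher number from compound 1 to compound 3 (0.04 log units; within the scatter) shows that two different groups at this aromatic carbon leave the number within the scatter, but both of them carry an aromatic ring, which compound 4 lacks. The change a 1.2-fold lower number from compound 2 to compound 3 (0.09 log units; within the scatter) concerns the carbonyl carbon and is also within the scatter. Among the measured compounds shown here, since no measured compound carries an open chain at this position, the account expects a moderate rise in the number for compound 4, with wide uncertainty; the expected step is a 2.7-fold higher number from compound 2 to compound 4 (0.42 log units; beyond the scatter). Compound 4 is therefore estimated at 250 nM, with a range from 80 nM to 800 nM.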

Compound 4, half-maximal effective concentration: 233 nM
Beside the measured number, compound 4's estimate is 1.1-fold (0.03 log units) above it; the range from low to high includes it.
By their numbers in this assay, from the lowest: compounds 1, 3 and 2 (each within the scatter of the next); then compound 4.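

Among these compounds, on the aromatic carbon para to a large group, replacing 3-chlorophenyl with 3-methoxyprop-1-en-1-yl produces the first change at this position that lies beyond the scatter in this assay (a 2.5-fold higher number from compound 2 to compound 4 (0.39 log units; beyond the scatter)). The earlier change at this carbon (a 1.1-fold higher number from compound 1 to compound 3 (0.04 log units; within the scatter)) exchanged one ring-bearing group for another and stayed within the scatter, whereas the group in compound 4 has no ring and still leaves only a modest step. Nothing available explains this step.

The compounds shown cannot separate the loss of the aromatic ring from the arrival of the methoxy oxygen, since both changes occur together in compound 4. Going by these compounds, it also remains open how a plain propenyl chain, or a chain ending in an amine or a carboxylic acid, would read at this carbon.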